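This account rests on a few compounds, and the source may have more. Where it says the series, first, only, none or still open, it means among the compounds named here.

Working notes on the series.

Compound 3 `Cc1[nH]c2ccccc2c1-c1ccnc(Nc2ccccc2Cl)n1` holds the highest number of the three measured in an assay on isolated protein for inhibition of interferon-induced, double-stranded RNA-activated protein kinase (Homo sapiens), read by luminescence, with a stated time of 10 min (on this read-out lower numbers stand for stronger inhibition and higher numbers for weaker inhibition), where compound 3 gives 19000 nM. Its nearest neighbour is compound 1 `Cc1[nH]c2ccccc2c1-c1ccnc(NCCO)n1`, which in this assay gives 11000 nM; that gap, a 1.7-fold higher number from compound 1 to compound 3 (0.24 log units; within the scatter), is within the scatter. The furthest is compound 2 `Cc1[nH]c2ccccc2c1-c1ccnc(Nc2cccc(Cl)c2)n1`, which gives 300 nM in this assay; the step of a 63-fold higher number from compound 2 to compound 3 (1.80 log units; beyond the scatter) is large, as is a 37-fold lower number from compound 1 to compound 2 (1.56 log units; beyond the scatter).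

Compound 4 `Cc1[nH]c2ccccc2c1-c1ccnc(Nc2ccc(F)cc2)n1` differs from compound 3 by 4-fluorophenyl in place of 2-chlorophenyl on a nitrogen on an aromatic ring. For the measured compounds named here, no measured step covers a 4-fluorophenyl group, so the only direct bearing comes from the pair of chlorophenyl compounds: moving the chlorine from one position to another shifted the number by a 63-fold higher number from compound 2 to compound 3 (1.80 log units; beyond the scatter), showing that where the halogen sits on the phenyl ring can move the read-out a great deal. Because compound 3 stands at 19000 nM while compound 2 stands at 300 nM, a fluorine in the third available position is expected to land between them, and the step of a 9.5-fold lower number from compound 3 to compound 4 (0.98 log units; beyond the scatter) is expected to be a lower number, beyond the scatter. Compound 4 is estimated at 2000 nM in this assay, with a range from 300 nM to 12000 nM.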

Compound 4, half-maximal inhibitory concentration: 150 nM
The estimate for compound 4 lay 13-fold (1.12 log units) above the measured number; measured number below the stated range.
By their numbers in this assay, from the lowest: compounds 4 and 2 (each within the scatter of the next); then compounds 1 and 3 (each within the scatter of the next).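

In this assay the step of a 130-fold lower number from compound 3 to compound 4 (2.10 log units; beyond the scatter) is large, so a low number on this nitrogen is not tied to 3-chlorophenyl alone. The step of a 2.0-fold lower number from compound 2 to compound 4 (0.30 log units; within the scatter) leaves 4-fluorophenyl and 3-chlorophenyl not separable, while a 73-fold lower number from compound 1 to compound 4 (1.87 log units; beyond the scatter) gives a second halogen-bearing phenyl group well clear of 2-hydroxyethyl, with 2-chlorophenyl in compound 3 going against any rule that phenyl groups outdo that chain. No measurement to hand bears on why these groups differ.

From the compounds shown here alone, the halogen and its place on the ring change together from compound 3 to compound 4, so the contribution of each alone stays open. Also open, going by these compounds, is how an unsubstituted phenyl, a 4-chlorophenyl or a 2-fluorophenyl group would read on this nitrogen.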